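This account rests on a few compounds, and the source may have more. Where it says the series, first, only, none or still open, it means among the compounds named here.

Of the compounds shown here, three built on one shared core have been tested in an ADME assay on THP-1 cells (Homo sapiens) for cytotoxicity, read by MTT assay, with a stated time of 72 h; on this read-out higher numbers stand for lower toxicity in this test and lower numbers for higher toxicity in this test. Compound 1 `O[C@@H]1Cc2ccccc2N[C@H](c2ccccc2)C1` is the simplest of them. For compound 1 the result in this assay is a limit of the assay, > 300000 nM, and not a number. Compound 2 `O[C@@H]1Cc2ccccc2N[C@H](c2cccc(Cl)c2)C1` differs from compound 1 by chloro in place of hydrogen on an aromatic carbon. In this assay compound 2 gives 167000 nM, so that an at least 1.7-fold lower number from compound 1 to compound 2 (0.25 log units; that floor lies within the scatter). Compound 3 `O[C@@H]1Cc2ccccc2N[C@H](c2c(Cl)cccc2Cl)C1` differs from compound 1 in a way that is not broken down here. For compound 3 the result in this assay is again a limit, > 300000 nM, not a number. Two of the three values thus sit at the limit of > 300000 nM in this assay, at which 2 of the 3 values shown sit.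

Compound 4 `O[C@@H]1Cc2cc(Cl)ccc2N[C@H](c2c(Cl)cccc2Cl)C1` has not yet been measured. It differs from compound 3 by chloro in place of hydrogen on an aromatic carbon, the same kind of change as from compound 1 to compound 2, though the surroundings differ: in compound 2 the chloro sits meta to a large group, whereas in compound 4 it sits on a ring that is part of a fused or bridged system of two rings, meta to a fused ring and para to a fused ring. The expected step of an at least 1.5-fold lower number from compound 3 to compound 4 (0.17 log units; that floor lies within the scatter) rests on the earlier step of an at least 1.7-fold lower number from compound 1 to compound 2 (0.25 log units; that floor lies within the scatter). For compound 4 in this assay the estimate is 200000 nM, expected to fall between 80000 nM and 400000 nM.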

Compound 4, half-maximal cytotoxic concentration: 59600 nM
Beside the measured number, compound 4's estimate is 3.4-fold (0.53 log units) above it; the whole stated range lies above it.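

In this assay, chloro in place of hydrogen on an aromatic carbon, on a ring that is part of a fused or bridged system of two rings, gives an at least 5.0-fold lower number from compound 3 to compound 4 (0.70 log units; beyond the scatter), so on this core the change goes with higher toxicity in this test. Set beside the earlier case, the change goes with a lower number on both cores, but the chloro sits on a different ring in each, and the comparison does not establish that the effect carries over with the same size: the same change on two cores in this assay, an at least 1.7-fold lower number (0.25 log units; that floor lies within the scatter) from compound 1 to compound 2 and an at least 5.0-fold lower number (0.70 log units; beyond the scatter) from compound 3 to compound 4; the limit leaves it open whether they differ Both steps start from a limit of the assay, their true sizes stay unknown, and two pairs of compounds make no rule for the whole series: the limit of > 300000 nM in this assay, at which 2 of the 4 values shown sit.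

The compounds shown leave open whether chloro at this same place would give a similar step on compound 1, which has no chloro on its other ring. They also leave open whether a fluoro group, a methoxy group or an amine at that place would lower the number as chloro does.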